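The source may hold more compounds than are shown below. What is called first, only, known or untested is meant among the compounds shown, and "the series" means these compounds.

Of the compounds shown here, three have been measured so far in a physicochemical assay for solubility, with a stated time of 18 h, at pH 7.4; on this read-out higher numbers stand for higher solubility and lower numbers for lower solubility. Compound 1, with the structure `COc1ccc(F)cc1CNCCCNc1ccnc2cc(C3CCCCC3)ccc12`, gives 4200 nM in this assay. Compound 2, `CC(C)CCc1ccc2c(NCCCNCc3ccco3)ccnc2c1`, gives 4200 nM, which sits level with compound 1 within the usual scatter, so no order can be drawn between the two; together they share the lowest solubility of the three. Compound 3, `COc1cccc(CNCCCNc2ccnc3cc(-c4ccc(C(F)(F)F)cc4)ccc23)c1O`, gives 32000 nM, a number that stands clearly beyond the scatter above compound 1.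

The step of interest leads from compound 1 to compound 4, whose structure is `COc1ccc(F)cc1CNCCCNc1ccnc2cc(Cc3ccc(F)cc3)ccc12`. The change is this: 4-fluorobenzyl in place of cyclohexyl on an aromatic carbon. Going by the values given here, no pair of measured compounds differs in only this one place, so the direction of the step can only be estimated. Compound 3 carries a different aromatic group at the same kind of place and shows a higher number, but it also differs elsewhere, so it offers only a loose hint.

The step from compound 1 to compound 4 is expected to be small, a 1.4-fold higher number from compound 1 to compound 4 (0.15 log units; within the scatter), likely inside the scatter. Compound 4 is therefore estimated at 6000 nM, in a range from 2000 nM to 20000 nM.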

Compound 4, solubility: 4200 nM
Beside the measured number, compound 4's estimate is 1.4-fold (0.15 log units) above it; the range from low to high includes it.
By their numbers in this assay, from the lowest: compounds 1, 2 and 4 (each within the scatter of the next); then compound 3.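

In this assay, going by these compounds alone, placing 4-fluorobenzyl where cyclohexyl stood on this aromatic carbon gives no change at the digits printed from compound 1 to compound 4 (within the scatter), the first direct reading of a change at this position with everything else in the molecule held fixed. A non-aromatic ring of carbon gives way to a larger group with an aromatic ring and a fluorine, both without hydrogen-bond donors, acceptors or net charge, and for this one pair the read-out stays level. No measurement shown here offers an explanation for this result.

The compounds shown leave open whether a group of a different kind at this place, such as one carrying an amine or a carboxylic acid, would move the number beyond the scatter. They also leave open whether this same exchange would read the same if another part of compound 1 were changed.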